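The compounds below may be only part of what the source reports. "The series", "measured", "known", "first", "only" and "open" are said of these compounds alone.

Measured compounds:
Compound 1 `Cc1ccc(C2CCN(CC(=O)Nc3cccc(C)c3)CC2)nc1` gives 41.7 nM in an assay on HEK293 cells for displacement of a labelled ligand from D(4) dopamine receptor (Homo sapiens), read by scintillation counting, with a stated time of 60 min; on this read-out higher numbers stand for weaker inhibition and lower numbers for stronger inhibition.
Compound 2 `Cc1cccc(NC(=O)CCN2CCC(c3ccccn3)CC2)c1` reaches only a limit of > 10000 nM in this assay.

Among the compounds with values here, compound 1 is the only compound with an actual number in this assay, and so it is the reference point of the set. Within the data shown here, compound 2 sits at the limit (the limit of > 10000 nM in this assay, at which 1 of the 2 values shown sits), which says only that it could not be quantified; no measured step between the two compounds exists, and nothing beyond what the two values show is claimed.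

Compound 3 `Cc1cccc(NC(=O)CN2CCC(c3ccc(Cl)cc3)CC2)c1` differs from compound 1 by 4-chlorophenyl in place of 5-methylpyridin-2-yl on a saturated ring carbon, with the rest of the shared core unchanged. Among the measured compounds shown here, no measured step of this kind is available, so the size and direction of the change are estimated without precedent. Compound 3 is expected to stay within the scatter of compound 1 or to gain modestly, a step of a 1.4-fold lower number from compound 1 to compound 3 (0.14 log units; within the scatter). Compound 3 is thus estimated at 30 nM in this assay, with a range from 8 nM to 120 nM.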

Compound 3, inhibition constant: 115 nM
The estimate for compound 3 lay 3.8-fold (0.58 log units) below the measured number; low and high end bracket the measured number.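

Within the data shown here, at this saturated ring carbon, three ring bonds from the ring nitrogen, the first measured change of the aromatic group has a modest cost in this assay: 4-chlorophenyl in place of 5-methylpyridin-2-yl gives a 2.8-fold higher number from compound 1 to compound 3 (0.44 log units; beyond the scatter). The exchange keeps the count of heavy atoms and removes the one hydrogen-bond acceptor of the leaving group, and compound 3 still gives a measured value of 115 nM. Nothing measured here bears on the cause of this step.

The exchange replaces the ring nitrogen and the methyl group with carbon and chlorine in a single step, so the compounds shown leave open which part of the change accounts for the loss. A 4-methylphenyl or 5-chloropyridin-2-yl group at this position would separate the two, while an unsubstituted phenyl group would show what the aromatic ring gives alone.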